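The compounds below may be only part of what the source reports. "The series", "measured", "known", "first", "only" and "open" are said of these compounds alone.

Compound 1 `CC(Nc1ncnc(N)c1C#N)c1nc2ccc(F)cc2c(O)c1-c1ccccc1`: 11.7 mL/min/kg
Compound 2 `C[C@H](Nc1ncnc(N)c1C#N)c1nc2ccc(F)cc2c(-c2ccccn2)c1-c1ccccn1`: 0.95 mL/min/kg

In an ADME assay on the whole organism (strain Sprague-Dawley) for pharmacokinetics, with Rattus norvegicus as the target (a higher number here means faster removal of the compound, a lower number slower removal), compound 2 gives 0.95 mL/min/kg, the lowest of the two numbers shown; compound 1 gives 11.7 mL/min/kg, a higher number that lies beyond the scatter. Compound 3 `Cc1cccnc1-c1c(-c2ccccn2)c([C@H](C)Nc2ncnc(N)c2C#N)nc2ccc(F)cc12` differs from compound 2 by methyl in place of hydrogen on an aromatic carbon. Among the compounds with values here, no pair of measured compounds shows this change. Compound 3 is expected to move by a 1.4-fold higher number from compound 2 to compound 3 (0.14 log units; within the scatter), a step within the scatter. Compound 3 is therefore estimated at 1.3 mL/min/kg in this assay, between 0.5 mL/min/kg and 3.5 mL/min/kg.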

Compound 3, clearance: 3.5 mL/min/kg
The estimate for compound 3 lay 2.7-fold (0.43 log units) below the measured number, and the stated range covers the measured number.
By their numbers in this assay, from the lowest: compound 2; then compound 3; then compound 1.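

Going from pyridin-2-yl to 3-methylpyridin-2-yl gives, in this assay, a 3.7-fold higher number from compound 2 to compound 3 (0.57 log units; beyond the scatter). This single-place step shows that one methyl on this aromatic carbon, two atoms from the ring nitrogen and ortho to a large group, is enough to speed removal beyond the scatter. No measurement offered here accounts for the shift. The compounds shown leave open whether an ethyl, a methoxy or an amine on the same carbon would move the number further, or back towards that of compound 2.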